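A few compounds are considered here, and "the series" means these few. Any claim that something is new, unique, unknown or untested is made for them only; others in the source may bear on it.

Two compounds share one core and differ only in the group carried on a saturated ring carbon. Compound 1 `COc1cc(N2C(N)=C(C#N)C(c3ccccc3O)C3=C2CC(C)(C)CC3=O)cc(OC)c1OC` carries a 2-hydroxyphenyl group there; in a functional assay on Ehrlich cells (Mus musculus) for cytotoxicity, tested at 10 ug/mL (a lower number here means a weaker effect, a higher number a stronger effect of the compound at the concentration tested), compound 1 gives 0%. Compound 2 `COc1cc(N2C(N)=C(C#N)C(c3ccc(OC)c4ccccc34)C3=C2CC(C)(C)CC3=O)cc(OC)c1OC` carries a 4-methoxynaphthalen-1-yl group instead, and in this assay compound 2 gives 10%. The step of a number 10 percentage points higher from compound 1 to compound 2 (within the scatter) is the only one measured so far. Among the compounds with values here, of the two numbers, the one for compound 2 is the upper one, but since the gap to compound 1 lies within the scatter, the two compounds are not told apart by this measurement.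

Compound 3 `COc1ccccc1C1C(C#N)=C(N)N(c2cc(OC)c(OC)c(OC)c2)C2=C1C(=O)CC(C)(C)C2` has not yet been measured in this assay. It differs from compound 2 at the same saturated ring carbon: 2-methoxyphenyl in place of 4-methoxynaphthalen-1-yl on a saturated ring carbon. Within the data shown here, the single step that bears on this position, a number 10 percentage points higher from compound 1 to compound 2 (within the scatter), was within the scatter, so a change of the group there has so far left the read-out in this assay essentially unmoved. Both measured values are low. For compound 3 the expected value in this assay is therefore 5%, with a range from 0% to 20%, which would mean an expected step of a number 5 percentage points lower from compound 2 to compound 3 (within the scatter), none beyond the scatter.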

Compound 3, a percentage reported as activity, at one concentration (the size of the read-out at that concentration, not a potency): 30%
The estimate for compound 3 lay 25 percentage points below the measured number, and the stated range ends below it.
By their numbers in this assay, from the lowest: compounds 1 and 2 (each within the scatter of the next); then compound 3.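

The group on the saturated ring carbon does affect the read-out in this assay: the earlier pair showed no change beyond the scatter, whereas 2-methoxyphenyl in place of 4-methoxynaphthalen-1-yl gives a number 20 percentage points higher from compound 2 to compound 3 (beyond the scatter), a modest but real change. A change as small as methyl in place of hydrogen on the oxygen of the aromatic ring gives a number 30 percentage points higher from compound 1 to compound 3 (beyond the scatter), which places compound 3 highest of the three, though a methoxy group alone does not explain this, as compound 2 also carries one and stays with compound 1 within the scatter. No measurement here gives a reason for either step.

The compounds shown leave open whether the read-out depends on the oxygen substituent itself or on the single aromatic ring carrying it, which a 2-ethoxyphenyl, 2-aminophenyl or plain phenyl group at the same carbon would help to separate. Since each number comes from a single concentration, they also leave open how potency compares across the three compounds, and even compound 3 shows only a modest effect in this assay.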